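A few compounds are considered here, and "the series" means these few. Any claim that something is new, unique, unknown or untested is made for them only; others in the source may bear on it.

In an ADME assay on microsomes from liver (Homo sapiens) for metabolic stability, read by LC-MS, using NADPH, with stated times of 5 min and 30 min, at 37 degrees C (a lower number here means that the compound disappears faster, a higher number that the compound lasts longer), compound 1 `C[C@H](O)[C@@H](CCc1ccc(C(F)(F)F)cc1)n1cnc2c(N)ncnc21` gives > 0.5 h, which is a limit and not a number. Compound 2 `COC(=O)c1cccc(CC[C@H]([C@H](C)O)n2cnc3c(N)ncnc32)c1` gives > 0.5 h, again a limit. Compound 3 `C[C@H](O)[C@@H](CCc1cccc(-c2nccs2)c1)n1cnc2c(N)ncnc21` gives > 0.5 h, likewise a limit, so it cannot be ranked against the other two. The record so far comes down to the limit of > 0.5 h in this assay, at which 3 of the 3 values shown sit. The change to compound 4 `C[C@H](O)[C@@H](CCc1cccc(-c2cnccn2)c1)n1cnc2c(N)ncnc21` is pyrazin-2-yl in place of 1,3-thiazol-2-yl on an aromatic carbon. For the measured compounds named here, the one measured step that bears on it, a step that the two limits leave unreadable from compound 2 to compound 3, also replaced the group on this aromatic carbon, but its size cannot be read. No step beyond the scatter is therefore expected in this assay, and no direction can be given. The estimated step that the limit leaves unreadable from compound 3 to compound 4 reflects that expectation. For compound 4 the expected half-life is 0.7 h, with an estimated range from 0.35 h to 1.5 h.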

Compound 4, half-life: > 0.5 h
Compound 4 was reported as a limit (the forecaster's own chance of this, stated with the estimate: 75%); the middle value does not contradict the limit.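

In this assay compound 4 gives > 0.5 h, a limit and not a number. For the compounds shown here, no step from compound 2 or compound 3 to compound 4 can therefore be read. The compounds shown leave open how long each one actually lasts and whether these replacements matter: the limit of > 0.5 h in this assay, at which 4 of the 4 values shown sit.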